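This account rests on a few compounds, and the source may have more. Where it says the series, first, only, none or still open, it means among the compounds named here.

Series notes. Compound 1 `C=C(C)[C@@H]1CC=C(Cn2cc(COc3ccc(C4NC(=O)NC5=C4C(=O)CC(C)(C)C5)cc3)nn2)CC1` carries the shared core, and in a functional assay on 786-0 cells (Homo sapiens) for inhibition, read by sulforhodamine B assay, with a stated time of 48 h (a lower number here means a stronger inhibitor of growth, a higher number a weaker inhibitor of growth), compound 1 gives 53200 nM. Compound 2 `C=C(C)[C@@H]1CC=C(Cn2cc(COc3cccc(C4NC(=O)NC5=C4C(=O)CC(C)(C)C5)c3)nn2)CC1` has the same atoms joined differently; the difference between the two cores is not broken down here. In this assay compound 2 gives > 100000 nM, which is a limit of the assay and not a number. Compound 3 `C=C(C)[C@@H]1CC=C(Cn2cc(COc3cc(C4NC(=O)NC5=C4C(=O)CC(C)(C)C5)ccc3OC)nn2)CC1` differs from compound 2 by methoxy in place of hydrogen on an aromatic carbon. In this assay compound 3 gives > 100000 nM, again a limit rather than a number. The step that the two limits leave unreadable from compound 2 to compound 3 cannot be sized because both values sit at the limit of > 100000 nM in this assay, at which 2 of the 3 values shown sit. Compound 4 `C=C(C)[C@@H]1CC=C(Cn2cc(COc3ccc(C4NC(=O)NC5=C4C(=O)CC(C)(C)C5)cc3OC)nn2)CC1` differs from compound 1 by methoxy in place of hydrogen on an aromatic carbon, the same kind of change as from compound 2 to compound 3, though here the methoxy is ortho to a large group and meta to a large group, whereas in compound 3 it is ortho to a large group and para to a large group. Since compound 1 gives only 53200 nM and the earlier step is unreadable, the step of a 1.5-fold higher number from compound 1 to compound 4 (0.18 log units; within the scatter) is expected to be small or weakening. Compound 4 is estimated at about 80000 nM, between 30000 nM and 200000 nM, with a real chance of a limit only.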

Compound 4, concentration for total growth inhibition: > 100000 nM
Compound 4: a limit, no number; the forecaster's own chance of this, stated with the estimate: 45%; at least 1.2-fold (0.09 log units) between middle value and limit.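

In this assay, methoxy in place of hydrogen on an aromatic carbon of the core of compound 1 gives an at least 1.8-fold higher number from compound 1 to compound 4 (0.27 log units; that floor lies within the scatter). On these data alone, compound 4 gives > 100000 nM, which is a limit of the assay and not a number, so this step has only a floor and its true size remains unknown. The same change on the core of compound 2 cannot be read, so the two steps cannot be compared, and whether the change carries from one core to the other is neither supported nor contradicted: the limit of > 100000 nM in this assay, at which 3 of the 4 values shown sit.

As far as these compounds go, it remains open whether an amine or a carboxylic acid in place of the methoxy would give a number rather than a limit. The same question stands for a longer chain on that oxygen.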